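Iodo to amino on the thiazole alkyne series

The compounds below may be only part of what the source reports. "The series", "measured", "known", "first", "only" and "open" are said of these compounds alone.

Measured compounds:
- compound 1, `COc1cccc(C#Cc2csc(N)n2)c1`: 18.6 nM
- compound 2, `N#Cc1cccc(C#Cc2csc(I)n2)c1`: 4.2 nM
- compound 3, `Cc1nc(C#Cc2cc(F)cc(C#N)c2)cs1`: 0.08 nM

In an assay on brain for displacement of a labelled ligand from metabotropic glutamate receptor 5 (Rattus norvegicus) (on this read-out lower numbers stand for stronger inhibition and higher numbers for weaker inhibition), compound 2 stands second highest of the three numbers. Its nearest neighbour is compound 1, whose number is higher by a margin beyond the scatter; compound 3 lies furthest from it, with a far lower number, also beyond the scatter.

The unmeasured compound 4, `N#Cc1cccc(C#Cc2csc(N)n2)c1`, differs from compound 2 in one place only: amino in place of iodo on an aromatic carbon. The amino group sits on the aromatic carbon next to the ring nitrogen and the ring sulfur of the five-membered ring. For the measured compounds named here, no pair of measured compounds differs in this single place, so the size of the step cannot be read off directly. Compound 1 carries the same amino group on the same ring and gives 18.6 nM, while compound 2 with iodo gives 4.2 nM, though the two also differ on the benzene ring.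

The expectation is a step of moderate size toward a higher number, a 3.6-fold higher number from compound 2 to compound 4 (0.55 log units; beyond the scatter), with compound 4 estimated at 15 nM within 3 nM to 60 nM.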

Compound 4, inhibition constant: 0.9 nM
Compound 4: middle estimate off by 17-fold (1.22 log units), on the high side; measured number below the stated range.
By their numbers in this assay, from the lowest: compound 3; then compound 4; then compound 2; then compound 1.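

In this assay, the amino group on this aromatic carbon of the five-membered ring goes with a stronger result than iodo, with the cyano group kept in place: a 4.7-fold lower number from compound 2 to compound 4 (0.67 log units; beyond the scatter). With the amino group kept in place, cyano in place of methoxy gives a 21-fold lower number from compound 1 to compound 4 (1.32 log units; beyond the scatter), so the high number of compound 1 cannot be taken as a mark against the amino group itself. Nothing measured here bears on why either change moves the number in this direction.

Still open, from the compounds shown here alone, is whether a methylamino or acetamido group, or a chlorine atom, on the same carbon would follow the amino group or iodo. Also open, going by these compounds, is whether amino in place of iodo gives a step of similar size when a fluoro group is added to the cyano-bearing benzene ring.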